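The source may report more compounds than this note shows. Statements on the series, on what has been measured and on what is new or still open speak of the compounds shown alone.

Compound 3 `C=CC(=O)Nc1cccc(NC(=O)CSc2nc(Nc3ccccc3C)c3ccccc3n2)c1` gives 20400 nM in a functional assay on MDA-MB-231 cells (Homo sapiens) for inhibition, read by MTT assay, with a stated time of 72 h (on this read-out lower numbers stand for stronger inhibition and higher numbers for weaker inhibition), which is the highest of the two numbers reported so far. Compound 2 `O=C(CSc1nc(Nc2ccccc2)c2ccccc2n1)Nc1ccc(C(F)(F)F)cc1` gives 11100 nM in this assay, and the gap between compound 2 and compound 3 lies within the scatter, so no order between them can be stated. Compound 1 `O=C(CSc1nc(Nc2ccccc2)c2ccccc2n1)Nc1cccc(F)c1` is reported in this assay only as a limit, > 50000 nM. For the measured compounds named here, the one measured step, an at least 4.5-fold lower number from compound 1 to compound 2 (0.65 log units; beyond the scatter), concerns the aryl group on the amide-type nitrogen and rests on a limit of > 50000 nM in this assay, at which 1 of the 3 values shown sits, at one end.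

Compound 4 `C=CC(=O)Nc1cccc(NC(=O)CSc2nc(Nc3ccc(Br)cc3)c3ccccc3n2)c1` differs from compound 3 at another place: 4-bromophenyl in place of 2-methylphenyl on a nitrogen on an aromatic ring. Going by the values given here, no measured step touches the aryl group on the nitrogen on the aromatic ring, so the step of an at least 4.5-fold lower number from compound 1 to compound 2 (0.65 log units; beyond the scatter) does not bear on this change, and the data give no ground for a shift in either direction. The estimate for compound 4 in this assay is therefore the number of compound 3 carried over within the scatter, with a wide range to cover the unmeasured position: compound 4 is expected to give 20000 nM, between 6000 nM and 50000 nM, a step of a 1.0-fold lower number from compound 3 to compound 4 (0.01 log units; within the scatter) that is expected to stay within the usual scatter.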

Compound 4, half-maximal inhibitory concentration: 17300 nM
Compound 4: the middle estimate sits 1.2-fold (0.06 log units) above what was measured; low and high end bracket the measured number.
By their numbers in this assay, from the lowest: compounds 2, 4 and 3 (each within the scatter of the next). At a limit, above all of these: compound 1.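

For the compounds shown here, the one measured change at this place, 4-bromophenyl in place of 2-methylphenyl on a nitrogen on an aromatic ring, gives a 1.2-fold lower number from compound 3 to compound 4 (0.07 log units; within the scatter). In this assay, this change therefore leaves no readable shift, although the two aryl groups carry different substituents and the rest of the molecule is the same. This differs from the earlier step on the amide-type nitrogen, an at least 4.5-fold lower number from compound 1 to compound 2 (0.65 log units; beyond the scatter), but the compounds shown offer no measured property that could explain either result.

Going by these compounds alone, it remains open whether this nitrogen position would respond to other groups, such as an amine or a carboxylic acid on the aryl ring or a longer chain in place of the aryl group, and the single pair cannot separate the loss of 2-methyl from the gain of 4-bromo. Compound 1 is available only as a limit, and the one step on the amide-type nitrogen rests on it: the limit of > 50000 nM in this assay, at which 1 of the 4 values shown sits.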